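The compounds below may be only part of what the source reports. "The series", "measured", "known", "first", "only" and "open" are said of these compounds alone.

Measured in a functional assay on HCT-116 cells (Homo sapiens) for antiproliferative activity, read by MTT assay, with a stated time of 48 h (on this read-out lower numbers stand for stronger inhibition and higher numbers for weaker inhibition), so far:
- compound 1 `COc1ccc(CN(C(=O)CSc2nc3ccccc3s2)c2cc(OC)c(OC)c(OC)c2)cc1OC` gives 33900 nM
- compound 2 `COc1ccc(CN(C(=O)CSc2nc3ccccc3s2)c2cc(OC)c(OC)c(OC)c2)cc1N` gives 491 nM

Of these two, compound 2 has the lower number, 491 nM, and so the stronger inhibition. Compound 3 `COc1cc(N(Cc2ccc(Br)cc2)C(=O)CSc2nc3ccccc3s2)cc(OC)c1OC` changes one group of compound 2: 4-bromophenyl in place of 3-amino-4-methoxyphenyl on a saturated chain carbon bound to an amide-type nitrogen. Among the measured compounds shown here, only one measured step bears on this, a 69-fold lower number from compound 1 to compound 2 (1.84 log units; beyond the scatter), a large step seen when amino replaced methoxy on an aromatic carbon. For the measured compounds named here, compound 3 also has no such amino group, though no measured compound carries 4-bromophenyl. A higher number in this assay is therefore expected, and the estimated step is an 8.1-fold higher number from compound 2 to compound 3 (0.91 log units; beyond the scatter), a clear rise. For compound 3 the expected value is 4000 nM, within an estimated range of 700 nM to 25000 nM.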

Compound 3, half-maximal inhibitory concentration: 63800 nM
Compound 3: the middle estimate sits 16-fold (1.20 log units) below what was measured, outside the stated range (above it).
By their numbers in this assay, from the lowest: compound 2; then compounds 1 and 3 (each within the scatter of the next).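

In this assay, moving from 3-amino-4-methoxyphenyl to 4-bromophenyl on this saturated chain carbon gives a large rise (a 130-fold higher number from compound 2 to compound 3 (2.11 log units; beyond the scatter)). Replacing 3,4-dimethoxyphenyl with 4-bromophenyl, by contrast, leaves the number within the scatter (a 1.9-fold higher number from compound 1 to compound 3 (0.27 log units; within the scatter)), so among these three compounds only compound 2, the one carrying the amino group, stands apart. Nothing available explains this difference.

Going by these compounds, it remains open whether a hydroxyl group in place of the amino group of compound 2 would keep the low number. Equally open, on these data alone, is whether the amino group would do so alongside bromine, as in 3-amino-4-bromophenyl.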